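Methoxy removal at two places within a small series

This account rests on a few compounds, and the source may have more. Where it says the series, first, only, none or still open, it means among the compounds named here.

Measured so far:
compound 1, `COc1ccc2[nH]c(-c3ccccc3)c(C=C(C#N)C#N)c2c1`, 3100 nM
compound 2, `COc1ccc(-c2[nH]c3ccc(OC)cc3c2C=C(C#N)C#N)cc1`, 407 nM
compound 3, `COc1ccc2[nH]c(-c3ccccc3)c(/C=C(\C#N)S(=O)(=O)c3ccccc3)c2c1`, 3500 nM

All three were run in a functional assay on HT-29 cells (Homo sapiens) for inhibition, read by sulforhodamine B assay, with a stated time of 48 h; on this read-out lower numbers stand for stronger inhibition of growth and higher numbers for weaker inhibition of growth. Compound 1 and compound 3 lie within the scatter of each other, so nothing separates them here; compound 3 gives a higher number than compound 2, and the gap lies beyond the scatter. How the core of compound 3 differs from that of compound 2 is not broken down here.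

One change is measured once: a 7.6-fold higher number from compound 2 to compound 1 (0.88 log units; beyond the scatter), the change being the removal of a methoxy on the phenyl that hangs from the core, para to a large group.
hydrogen in place of methoxy on an aromatic carbon

Compound 4, `N#C/C(=C\c1c(-c2ccccc2)[nH]c2ccccc12)S(=O)(=O)c1ccccc1`, is not yet measured in this assay. It differs from compound 3 by the same kind of change, but at a different place: on a six-membered aromatic ring of carbon only, part of a fused system of two rings, meta to a fused ring and para to a fused ring.
hydrogen in place of methoxy on an aromatic carbon

For the measured compounds named here, because the one measured instance, a 7.6-fold higher number from compound 2 to compound 1 (0.88 log units; beyond the scatter), sits on the pendant phenyl and not on the fused ring, its size transfers only loosely. A weaker version of that rise is expected, a 2.0-fold higher number from compound 3 to compound 4 (0.30 log units; within the scatter), starting from compound 3 at 3500 nM. For compound 4 the estimate is 7000 nM, expected between 2500 nM and 20000 nM.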

Compound 4, concentration for 50% growth inhibition: 595 nM
Compound 4: the middle estimate sits 12-fold (1.07 log units) above what was measured; the whole stated range lies above it.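

In this assay, hydrogen in place of methoxy on the fused ring gives a 5.9-fold lower number from compound 3 to compound 4 (0.77 log units; beyond the scatter), so losing this methoxy goes with stronger inhibition of growth in this pair. Set beside the step on the pendant phenyl, the same kind of change does not carry over from one core to the other, even in direction: the same change on two cores in this assay, a 7.6-fold higher number (0.88 log units; beyond the scatter) from compound 2 to compound 1 and a 5.9-fold lower number (0.77 log units; beyond the scatter) from compound 3 to compound 4, 45-fold (1.65 log units) apart, beyond the scatter of two such steps. This does not show what separates the two outcomes, since the pairs differ both in the place of the methoxy and in the rest of the core, one carrying two nitriles and the other a nitrile with a phenylsulfonyl group, and each outcome rests on a single pair of compounds.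

Still open, as far as these compounds go, is how the step would read with the same methoxy replaced on the fused ring of compound 1, or with a methoxy on the pendant phenyl of compound 4, either of which would separate place from core. Also open, from the compounds shown here alone, is whether a hydroxy group, a fluorine or an amine on the same aromatic carbon would behave like the methoxy or like the hydrogen.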